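A few compounds are considered here, and "the series" means these few. Any claim that something is new, unique, unknown or untested is made for them only; others in the source may bear on it.

Compound 3, with structure `CCOC(=O)c1cnc(N2CCN(Cc3ccc(S(N)(=O)=O)cc3)CC2)nc1Oc1c(C)cc(-c2ccc(C#N)cc2)cc1C`, carries a 4-sulfamoylphenyl group on a saturated chain carbon bound to an amine nitrogen in a ring. In an ADME assay on MT4 cells (Homo sapiens) for cytotoxicity, read by MTT assay, with a stated time of 4 days (on this read-out lower numbers stand for higher toxicity in this test and higher numbers for lower toxicity in this test), compound 3 gives only a limit, >= 7930 nM, as the limit of >= 7930 nM in this assay, at which 1 of the 3 values shown sits, records. Compound 1, `CCOC(=O)c1cnc(N2CCN(Cc3ccc(F)cc3)CC2)nc1Oc1c(C)cc(-c2ccc(C#N)cc2)cc1C`, likewise gives only a limit in this assay, > 117000 nM. Compound 2, `CCOC(=O)c1cnc(N2CCN(Cc3cccc(C(=O)OC)c3)CC2)nc1Oc1c(C)cc(-c2ccc(C#N)cc2)cc1C`, gives the limit > 125000 nM in this assay as well. Every value is a limit. The steps a step that the two limits leave unreadable from compound 1 to compound 2, a step that the two limits leave unreadable from compound 1 to compound 3 and a step that the two limits leave unreadable from compound 2 to compound 3 cannot be sized. Compound 4, `CCOC(=O)c1cnc(N2CCN(Cc3cccc(OC)c3)CC2)nc1Oc1c(C)cc(-c2ccc(C#N)cc2)cc1C`, differs from compound 3 by 3-methoxyphenyl in place of 4-sulfamoylphenyl on a saturated chain carbon bound to an amine nitrogen in a ring. The measured steps bearing on this change, those ending at compound 3, give no readable size, so nothing beyond the scatter can be expected in this assay with confidence; the two higher limits of compound 1 and compound 2 suggest that compound 4 may again reach only a limit. Compound 4 is therefore expected to give 100000 nM, between 20000 nM and 250000 nM. The step from compound 3 to compound 4 is thus estimated at a step that the limit leaves unreadable from compound 3 to compound 4.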

Compound 4, half-maximal cytotoxic concentration: > 125000 nM
Compound 4 ended at the assay's limit (the forecaster's own chance of this, stated with the estimate: 70%); middle value at least 1.2-fold (0.09 log units) from the limit.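

In this assay compound 4 gives only a limit, > 125000 nM, and the steps to it from compound 1, compound 2 and compound 3 cannot be read. The compounds shown leave open whether these four benzyl variants on the shared core differ in cytotoxicity at all.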